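Bromo to Chloro Exchange on Two Related Cores

This account rests on a few compounds, and the source may have more. Where it says the series, first, only, none or still open, it means among the compounds named here.

Compound 1 `COc1ccc(C2=NN(C3=NC(=O)/C(=C4\C(=O)Nc5ccc(Br)cc54)S3)C(c3ccc(Cl)cc3)C2)cc1` — in a functional assay on cells (Cancer cell lines, Homo sapiens) for cytotoxicity, read by sulforhodamine B assay, with a stated time of 48 h (a higher number here means a weaker inhibitor of growth, a lower number a stronger inhibitor of growth), compound 1 gives 120 nM.
Compound 2 `COc1ccc(C2=NN(C3=NC(=O)/C(=C4\C(=O)Nc5ccc(Cl)cc54)S3)C(c3ccc(Cl)cc3)C2)cc1` — in this assay compound 2 gives 200 nM.
Compound 3 `COc1ccc(-c2cc(-c3ccc(Cl)cc3)n(C3C(=O)Nc4ccc(Br)cc43)n2)cc1` — in this assay compound 3 gives 7530 nM.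

Compound 1 and compound 2 share one core; compound 3 is built on another, and the difference between the two cores is not broken down here. Within the first pair, the change chloro in place of bromo on an aromatic carbon gave a 1.7-fold higher number from compound 1 to compound 2 (0.22 log units; within the scatter). Compound 3 stands apart from both, its number beyond the scatter above compound 2 and further still above compound 1. Compound 4 `COc1ccc(-c2cc(-c3ccc(Cl)cc3)n(C3C(=O)Nc4ccc(Cl)cc43)n2)cc1` has not been measured; it carries the same change, (chloro in place of bromo on an aromatic carbon), made on the core of compound 3, at the same place. Because the earlier step of a 1.7-fold higher number from compound 1 to compound 2 (0.22 log units; within the scatter) stayed within the scatter, the expected step for compound 4 is likewise small, a 1.5-fold higher number from compound 3 to compound 4 (0.16 log units; within the scatter). Compound 4 is therefore estimated at about 11000 nM in this assay, with an expected range from 4500 nM to 28000 nM.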

Compound 4, concentration for 50% growth inhibition: 4370 nM
Compound 4: middle estimate off by 2.5-fold (0.40 log units), on the high side; the whole stated range lies above it.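

In this assay the exchange on the core of compound 3 gave a 1.7-fold lower number from compound 3 to compound 4 (0.24 log units; within the scatter). Each step on its own stays within the scatter, yet the same change did not carry over as the same step from one core to the other: the same change on two cores in this assay, a 1.7-fold higher number (0.22 log units; within the scatter) from compound 1 to compound 2 and a 1.7-fold lower number (0.24 log units; within the scatter) from compound 3 to compound 4, 2.9-fold (0.46 log units) apart, beyond the scatter of two such steps. This rests on a single pair on each core, so it does not show why the two steps differ, or whether the difference would hold for other pairs on these cores. The compounds shown leave open what fluoro, an amine or a carboxylic acid would do at this same aromatic carbon on either core.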